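This account rests on a few compounds, and the source may have more. Where it says the series, first, only, none or still open, it means among the compounds named here.

Measured so far in a functional assay (ileum) for antagonist activity, with Cavia porcellus as the target; on this read-out lower numbers stand for stronger inhibition and higher numbers for weaker inhibition:
compound 1 `CC1=C(C(=O)OCCO[N+](=O)[O-])C(c2cccc3nonc23)C([N+](=O)[O-])=C(C)C1` — 3890 nM
compound 2 `CC1=C(C(=O)OCCCCO[N+](=O)[O-])C(c2cccc3nonc23)C([N+](=O)[O-])=C(C)C1` — 878 nM
compound 3 `CC1=C(C(=O)OC(C)CO[N+](=O)[O-])C(c2cccc3nonc23)C([N+](=O)[O-])=C(C)C1` — 6380 nM

Compound 3 gives the highest number of the three. Its nearest neighbour is compound 1, a 1.6-fold higher number from compound 1 to compound 3 (0.21 log units; within the scatter); its furthest is compound 2, a 7.3-fold higher number from compound 2 to compound 3 (0.86 log units; beyond the scatter). Compound 1 and compound 3 therefore cannot be ordered, whereas compound 2 sits clearly apart from both.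

Compound 4 `CC1=C(C(=O)OCC(C)O[N+](=O)[O-])C(c2cccc3nonc23)C([N+](=O)[O-])=C(C)C1` differs from compound 3 by a group of 7 heavy atoms (3 carbon, 1 nitrogen, 3 oxygen; no ring) in place of a group of 7 heavy atoms (3 carbon, 1 nitrogen, 3 oxygen; no ring), on an oxygen next to a carbonyl group; the two hold the same atoms, joined differently. Going by the values given here, the step that bears most directly on this is the one from compound 1 to compound 3, a 1.6-fold higher number from compound 1 to compound 3 (0.21 log units; within the scatter), which shows that placing a methyl on the chain changed little. The larger step, a 4.4-fold lower number from compound 1 to compound 2 (0.65 log units; beyond the scatter), concerns a longer chain and does not map onto this change. Moving the methyl along the chain is thus expected to give a step within the scatter, a 1.4-fold lower number from compound 3 to compound 4 (0.15 log units; within the scatter), with no clear direction. Compound 4 is estimated at 4500 nM, in the range 1500 nM to 13000 nM.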

Compound 4, half-maximal inhibitory concentration: 1700 nM
Compound 4: middle estimate off by 2.6-fold (0.42 log units), on the high side, and the stated range covers the measured number.
By their numbers in this assay, from the lowest: compounds 2 and 4 (each within the scatter of the next); then compounds 1 and 3 (each within the scatter of the next).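

In this assay joining the same atoms differently on the oxygen next to a carbonyl group gives a 3.8-fold lower number from compound 3 to compound 4 (0.57 log units; beyond the scatter) and so shows that where the methyl stands on this chain counts, which compound 1 and compound 3 alone could not show. The methyl of compound 4 also separates it from the unbranched chain, with a 2.3-fold lower number from compound 1 to compound 4 (0.36 log units; beyond the scatter) in contrast to the step printed earlier for compound 3. With a 1.9-fold higher number from compound 2 to compound 4 (0.29 log units; within the scatter) on record, 1-(nitrooxy)ethyl in place of 3-(nitrooxy)propyl leaves compound 4 and compound 2 unordered, so branching and chain length cannot be ranked against each other here.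

Open, going by these compounds, is whether a methyl on a longer chain, or an amine or a carboxylic acid in place of the nitrooxy group, would keep this activity. No measurement on hand accounts for the difference between the two methyl placements.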